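Cyclobutyl for allyl on the triazole nitrogen

This account rests on a few compounds, and the source may have more. Where it says the series, first, only, none or still open, it means among the compounds named here.

Among the measured compounds shown here, compound 2 `C=CCn1cc(COc2cc(O)c3c(c2)O[C@H](c2ccc(OC)c(O)c2)CC3=O)nn1` is one of two compounds measured in a functional assay on RAW264.7 cells (Mus musculus) for inhibition, read by Griess assay, with stated times of 2 h and 24 h; on this read-out higher numbers stand for weaker inhibition and lower numbers for stronger inhibition. In this assay compound 2 gives 13800 nM, and compound 1 `COc1ccc([C@@H]2C/C(=N\O)c3c(O)cc(OCc4cn(Cc5ccccc5C)nn4)cc3O2)cc1O` gives 18000 nM; the two numbers sit within the scatter of each other, so neither stands apart. Compound 3 `COc1ccc([C@@H]2CC(=O)c3c(O)cc(OCc4cn(C5CCC5)nn4)cc3O2)cc1O` has not been measured. It differs from compound 2 in one place (cyclobutyl in place of allyl on an aromatic nitrogen). For the measured compounds named here, no step between measured compounds is available, so the expected step of a 1.1-fold lower number from compound 2 to compound 3 (0.03 log units; within the scatter) is small and not beyond the scatter. Compound 3 is therefore expected to give about 13000 nM, within a range from 5000 nM to 35000 nM.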

Compound 3, half-maximal inhibitory concentration: 15300 nM
Compound 3: middle estimate off by 1.2-fold (0.07 log units), on the low side; the range from low to high includes it.
By their numbers in this assay, from the lowest: compounds 2, 3 and 1 (each within the scatter of the next).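

In this assay, placing cyclobutyl instead of allyl on the aromatic nitrogen gives a 1.1-fold higher number from compound 2 to compound 3 (0.04 log units; within the scatter). Among the compounds shown here, at this position, then, a four-membered carbon ring and an open allyl chain are not told apart by this read-out, which the earlier compounds, differing in more than one place, could not show. No measurement shown here offers an explanation for this result. From the compounds shown here alone, whether an amine, a carboxylic acid or a longer chain on this nitrogen would give a number beyond the scatter remains open.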